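Amino for Chloro on the Fused Ring of Compound 2

The source may report more compounds than this note shows. Statements on the series, on what has been measured and on what is new or still open speak of the compounds shown alone.

Compound 2 `Nc1nn(C(=O)Nc2ccc(Cc3ccccc3)cc2)c2ccc(Cl)cc12` gives 33700 nM in a functional assay on HOP-92 cells (Homo sapiens) for antiproliferative activity, read by sulforhodamine B assay, with a stated time of 48 h; a lower number here means a stronger inhibitor of growth, a higher number a weaker inhibitor of growth. For the measured compounds named here, the only companion number comes from compound 1 `Nc1nn(C(=O)Nc2ccc(Cc3ccccc3)cc2)c2ccccc12`, which gives 42600 nM in this assay, within the scatter of compound 2. Going by the values given here, the one measured step, a 1.3-fold lower number from compound 1 to compound 2 (0.10 log units; within the scatter), put chloro in place of hydrogen on an aromatic carbon and stayed within the scatter. Compound 3 `Nc1ccc2c(c1)c(N)nn2C(=O)Nc1ccc(Cc2ccccc2)cc1` carries amino in place of chloro on an aromatic carbon. Among the compounds with values here, with only that small step to go on, no shift beyond the scatter is expected. Compound 3 is estimated at 38000 nM, between 15000 nM and 95000 nM. That estimate means a step of a 1.1-fold higher number from compound 2 to compound 3 (0.05 log units; within the scatter).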

Compound 3, concentration for total growth inhibition: 24400 nM
Beside the measured number, compound 3's estimate is 1.6-fold (0.19 log units) above it; low and high end bracket the measured number.
By their numbers in this assay, from the lowest: compounds 3, 2 and 1 (each within the scatter of the next).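

In this assay the change from chloro to amino gives a 1.4-fold lower number from compound 2 to compound 3 (0.14 log units; within the scatter) and the change from hydrogen to amino gives a 1.7-fold lower number from compound 1 to compound 3 (0.24 log units; within the scatter) at this aromatic carbon. Hydrogen, chloro and amino therefore cannot be told apart here, even though amino alone brings a hydrogen-bond donor and acceptor. From the compounds shown here alone, whether a carboxylic acid or a methoxy group on this carbon would move the number beyond the scatter stays open. No measurement at hand offers a reason for this flat result.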